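Butyl Amide in Place of a Fluorophenyl Amide

This account rests on a few compounds, and the source may have more. Where it says the series, first, only, none or still open, it means among the compounds named here.

Of the compounds shown here, three built on one shared core have been tested in an ADME assay on Vero cells (Chlorocebus sabaeus) for cytotoxicity, read by MTT assay, with a stated time of 72 h; on this read-out higher numbers stand for lower toxicity in this test and lower numbers for higher toxicity in this test. Compound 3 `O=C(c1ccc(F)cc1)N1CCN(c2nc(=O)c3cc(C(F)(F)F)cc([N+](=O)[O-])c3s2)CC1` gives only a limit in this assay, > 125000 nM. Compound 1 `O=C(c1cccc(F)c1)N1CCN(c2nc(=O)c3cc(C(F)(F)F)cc([N+](=O)[O-])c3s2)CC1` reaches only the limit as well, > 125000 nM. Compound 2 `O=c1nc(N2CCN(CC3CCCCC3)CC2)sc2c([N+](=O)[O-])cc(C(F)(F)F)cc12` gives a limit too, > 125000 nM. For that reason the steps a step that the two limits leave unreadable from compound 1 to compound 3, a step that the two limits leave unreadable from compound 1 to compound 2 and a step that the two limits leave unreadable from compound 2 to compound 3 cannot be sized, as summed up by the limit of > 125000 nM in this assay, at which 3 of the 3 values shown sit. Compound 4 `CCCCC(=O)N1CCN(c2nc(=O)c3cc(C(F)(F)F)cc([N+](=O)[O-])c3s2)CC1` differs from compound 3 in one place: butyl in place of 4-fluorophenyl on a carbonyl carbon. Among the compounds with values here, with no measured step giving a size or a direction, the expectation is that the step that the limit leaves unreadable from compound 3 to compound 4 remains hidden at the limit. Compound 4 is therefore estimated at 150000 nM, with a range from 60000 nM to 400000 nM.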

Compound 4, half-maximal cytotoxic concentration: > 125000 nM
Compound 4: a limit, no number (the forecaster's own chance of this, stated with the estimate: 85%); the middle value lies beyond the limit too.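

Compound 4 gives only a limit in this assay, as do compound 1, compound 2 and compound 3, so no step among them can be read: the limit of > 125000 nM in this assay, at which 4 of the 4 values shown sit.

Still open, on these data alone, is whether these four compounds differ at all in this assay, and by how much.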